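Shifting the methyl around the phenoxy ring

This account rests on a few compounds, and the source may have more. Where it says the series, first, only, none or still open, it means among the compounds named here.

Compound 1, `NS(=O)(=O)c1sc(Cl)cc1-c1csc(-c2ccccc2COc2ccc(Cl)cc2)n1`: 76.4%
Compound 2, `Cc1ccccc1OCc1ccccc1-c1nc(-c2cc(Cl)sc2S(N)(=O)=O)cs1`: 70.1%

In a functional assay on the whole organism (strain Wistar albino) for inhibition, with Rattus norvegicus as the target, read by paw edema, at a dose of 10 mg/kg by the oral route (a higher number here means more inhibition at the dose given (going by the name of the read-out), a lower number less inhibition), compound 1 gives 76.4% and compound 2 gives 70.1%. Within the data shown here, of the two numbers, the one for compound 2 is the smaller, yet the single measured step, a number 6.3 percentage points lower from compound 1 to compound 2 (within the scatter), is within the scatter, so the two compounds cannot be told apart. Compound 3, `Cc1cccc(OCc2ccccc2-c2nc(-c3cc(Cl)sc3S(N)(=O)=O)cs2)c1`, has not been measured. It differs from compound 2 by 3-methylphenyl in place of 2-methylphenyl on an oxygen on a saturated carbon. Among the measured compounds shown here, the only step that bears on this change is the one from compound 1 to compound 2, which swapped the aryl on the same oxygen and produced nothing beyond the scatter. No step beyond the scatter is therefore expected for a number 0.1 percentage points lower from compound 2 to compound 3 (within the scatter). Compound 3 is estimated at 70%, within 58% to 80%.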

Compound 3, a percentage reported as inhibition, in the whole organism at one dose (the size of the read-out at that dose, not a potency): 66.8%
For compound 3 the middle estimate is 3.2 percentage points above the measured one, and the stated range covers the measured number.
By their numbers in this assay, from the lowest: compounds 3, 2 and 1 (each within the scatter of the next).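

Within this assay the shift from 2-methylphenyl to 3-methylphenyl gives a number 3.3 percentage points lower from compound 2 to compound 3 (within the scatter) and so leaves the two groups impossible to tell apart on this oxygen. The swap of 4-chlorophenyl for 3-methylphenyl gives a number 9.6 percentage points lower from compound 1 to compound 3 (within the scatter) and so separates those two groups no better. Nothing available speaks to what lies behind these readings.

The compounds shown leave open whether any group at this position would move the number beyond the scatter. A carboxylic acid or an amine on the ring, or a longer chain in place of the methyl, might do so.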